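This account rests on a few compounds, and the source may have more. Where it says the series, first, only, none or still open, it means among the compounds named here.

Compound 1, `CCCCCCCCCCn1cc(-c2nc3ccccc3cc2CCCCC)nn1`: in a functional assay on THP-1 cells (Homo sapiens) for cytotoxicity, read by MTT assay, with a stated time of 24 h (a higher number here means a weaker inhibitor, a lower number a stronger inhibitor), compound 1 gives 88 ug/mL.
Compound 2, `Cc1cc2ccccc2nc1-c1cn(-c2ccc(F)cc2)nn1`: in this assay compound 2 reaches only the limit of the measurement, > 100 ug/mL.
Compound 3, `CCc1cc2ccccc2nc1-c1cn(CCC(F)(F)C(F)(F)C(F)(F)C(F)(F)C(F)(F)C(F)(F)C(F)(F)C(F)(F)F)nn1`: in this assay compound 3 likewise reaches only the limit, > 100 ug/mL.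

Compound 3 therefore does not stand at a measured number at all; it sits at the limit of > 100 ug/mL in this assay, at which 2 of the 3 values shown sit, and so it cannot be placed in order against compound 1 or compound 2 beyond saying that its reading is a limit. The next compound, compound 4, `Cc1cc2ccccc2nc1-c1cn(CCC(F)(F)C(F)(F)C(F)(F)C(F)(F)C(F)(F)C(F)(F)C(F)(F)C(F)(F)F)nn1`, is built from compound 3 by one change: hydrogen in place of methyl on a saturated chain carbon bound to an aromatic carbon. Read one bond further out, this is ethyl to methyl, or 3-ethylquinolin-2-yl to 3-methylquinolin-2-yl. For the measured compounds named here, no pair of measured compounds here differs in just this way, so no measured step shows what such a change does in this assay.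

With compound 3 already at the limit and compound 2, which also carries a methyl on this chain carbon, at the same limit, the expectation is that compound 4 moves by a number no higher from compound 3 to compound 4 (the limit leaves the size open), that is, by no step beyond the scatter, and most likely stays at the limit. Compound 4 is estimated at 100 ug/mL, with a range from 50 ug/mL to 200 ug/mL.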

Compound 4, half-maximal inhibitory concentration: > 100 ug/mL
Compound 4: a limit, no number; the forecaster's own chance of this, stated with the estimate: 75%; the middle value sits exactly at the limit.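

Compound 3 and compound 4 each give only a limit in this assay, not a number, so no step can be read for the change from ethyl to methyl: the limit of > 100 ug/mL in this assay, at which 3 of the 4 values shown sit.

The compounds shown leave open whether this change from ethyl to methyl alters the reading in this assay at all.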